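Swapping the amide head group within the shared core

A few compounds are considered here, and "the series" means these few. Any claim that something is new, unique, unknown or untested is made for them only; others in the source may bear on it.

Compound 3 `Nc1ccccc1NC(=O)c1ccc(COc2ccccc2)cc1` is one of two compounds returning a number in a functional assay on HepG2 cells (Homo sapiens) for antiproliferative activity, read by CCK-8 assay, with a stated time of 72 h (a lower number here means a stronger inhibitor, a higher number a weaker inhibitor), at 6700 nM. Compound 1 `O=C(/C=C/c1ccc(COc2ccccc2)cc1)NO` lies within the scatter of it in this assay at 8400 nM. Compound 2 `Nc1ccccc1NC(=O)c1ccc(COc2ccc(Br)cc2)cc1` reaches only a limit in this assay, > 32000 nM. Among the compounds with values here, the single measured step, an at least 4.7-fold lower number from compound 2 to compound 3 (0.67 log units; beyond the scatter), concerns the bromo, and the limit of > 32000 nM in this assay, at which 1 of the 3 values shown sits, caps how far it can be sized. Compound 4 `O=C(NO)c1ccc(COc2ccccc2)cc1` differs from compound 3 by hydroxy in place of 2-aminophenyl on an amide-type nitrogen. Within the data shown here, no measured step touches the amide-type nitrogen, so none bears directly on this move; the only guide is that compound 1, carrying the hydroxyamino group, gives 8400 nM, within the scatter of compound 3. Compound 4 is therefore expected to stay close, with a step of a 1.2-fold lower number from compound 3 to compound 4 (0.09 log units; within the scatter), estimated at 5500 nM (range 1500 nM to 20000 nM).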

Compound 4, half-maximal inhibitory concentration: 29600 nM
The estimate for compound 4 lay 5.4-fold (0.73 log units) below the measured number; measured number above the stated range.
By their numbers in this assay, from the lowest: compounds 3 and 1 (each within the scatter of the next); then compound 4. At a limit, above all of these: compound 2.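

On the amide-type nitrogen, hydroxy in place of 2-aminophenyl is not a neutral swap: this assay shows a 4.4-fold higher number from compound 3 to compound 4 (0.65 log units; beyond the scatter) for this change. On an aromatic carbon, hydroxycarbamoyl in place of 2-(hydroxycarbamoyl)ethenyl gives a 3.5-fold higher number from compound 1 to compound 4 (0.55 log units; beyond the scatter) in the same read-out. The hydroxyamino group alone therefore does not hold the level of compound 1, and the group carrying it matters at this position.

Open, on these data alone, is how a carboxylic acid in place of hydroxycarbamoyl, or a longer chain carrying hydroxycarbamoyl, would read in this assay against compound 4. Nothing measured here accounts for either step.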